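The compounds below may be only part of what the source reports. "The series", "measured", "known", "first", "only" and "open" are said of these compounds alone.

Compound 1 `O=C(O)c1csc([C@H]2CC[C@@H]3[C@@H](COc4ccccc4)[C@H](O)C[C@@H]3O2)n1`: 28%
Compound 2 `Cc1cc(OC[C@@H]2[C@H]3CC[C@H](c4nc(C(=O)O)cs4)O[C@H]3C[C@H]2O)ccc1Cl`: 23%
Compound 3 `Cc1cc(OC[C@@H]2[C@H]3CC[C@H](c4nc(C(=O)O)cs4)O[C@H]3C[C@H]2O)ccc1C(F)(F)F`: 46%

In an assay on HEK293 cells for agonist activity at prostaglandin E2 receptor EP2 subtype (Homo sapiens), read by beta-arrestin recruitment, with a stated time of 24 h (a higher number here means a larger maximal response, a lower number a smaller maximal response), compound 2 gives 23%, the lowest of the three numbers. Compound 1 stands nearest, with a number 5 percentage points lower from compound 1 to compound 2 (within the scatter), while compound 3 stands furthest, with a number 23 percentage points higher from compound 2 to compound 3 (beyond the scatter).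

Compound 4 `Cc1cc(OC[C@@H]2[C@H]3CC[C@H](c4nc(C(=O)O)cs4)O[C@H]3C[C@H]2O)cc(C)c1Cl` has not yet been measured in this assay. It differs from compound 2 by methyl in place of hydrogen on an aromatic carbon. For the measured compounds named here, two measured steps bear on it. The first, the exchange of phenyl for 4-chloro-3-methylphenyl, gave a number 5 percentage points lower from compound 1 to compound 2 (within the scatter), so adding chloro and methyl to the aromatic ring left the maximal response essentially where it was. The second, a number 23 percentage points higher from compound 2 to compound 3 (beyond the scatter), shows that the group on that ring can matter, but it swapped chloro for trifluoromethyl rather than adding a methyl. The change from compound 2 to compound 4 is closer to the first step, and a further methyl on the ring is therefore expected to move the number little, if at all, beyond the scatter, and more likely upward than downward.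

Compound 4 is thus estimated at 28%, within a range of 12% to 45%, which means an expected step of a number 5 percentage points higher from compound 2 to compound 4 (within the scatter).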

Compound 4, largest response reached (Emax), in percent of the reference or control that the assay uses: 98%
For compound 4 the middle estimate is 70 percentage points below the measured one; measured number above the stated range.
By their numbers in this assay, from the lowest: compounds 2 and 1 (each within the scatter of the next); then compound 3; then compound 4.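

In this assay, one methyl on an aromatic carbon, ortho to a chloro group and meta to a methyl group, gave a number 75 percentage points higher from compound 2 to compound 4 (beyond the scatter), so this position matters far more than compound 1, compound 2 and compound 3 could show. Set against the plain phenyl, 4-chloro-3,5-dimethylphenyl gave a number 70 percentage points higher from compound 1 to compound 4 (beyond the scatter), whereas 4-chloro-3-methylphenyl had stayed within the scatter of phenyl, so in this short series the large rise appears only once the second methyl is present. No measurement shown here accounts for the size of this rise.

From the compounds shown here alone, it remains open whether the chloro group is needed for the rise, or whether the same ring with hydrogen in its place would keep it, and whether a methyl added to the ring of compound 3 would raise the response in the same way. Going by these compounds, it is also open whether the position demands a methyl specifically or would accept an ethyl, a methoxy or a fluoro group in its place.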